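A few compounds are considered here, and "the series" means these few. Any claim that something is new, unique, unknown or untested is made for them only; others in the source may bear on it.

Compound 1 `COc1ccc(CNc2nc3cc(N)cc(N)c3nc2-c2ccccc2)cc1OC` — 16200 nM
Compound 2 `CCOC(=O)[C@H](CCC(=O)O)NC(=O)c1ccc(Sc2nc3cc(N)cc(N)c3nc2-c2ccccc2)cc1` — 32400 nM

Two compounds carry numbers in a functional assay on SNB-75 cells (Homo sapiens) for inhibition, read by sulforhodamine B assay, with a stated time of 48 h; a lower number here means a stronger inhibitor of growth, a higher number a weaker inhibitor of growth. Compound 1 gives 16200 nM, and compound 2 gives 32400 nM. Compound 1 thus holds the lower of the two numbers, but the gap to compound 2 falls within the scatter of repeated measurements, so the two cannot be ranked against each other on this evidence.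

Compound 3 `COc1cc(CNc2nc3cc(N)cc(N)c3nc2-c2ccccc2)cc(OC)c1OC` has not yet been measured. It differs from compound 1 by methoxy in place of hydrogen on an aromatic carbon. Among the compounds with values here, no pair of measured compounds shows what such an addition does in this assay, so there is nothing to draw a step from; the expectation rests on compound 1 alone. Because compound 1 gives 16200 nM, the step of a 1.2-fold lower number from compound 1 to compound 3 (0.06 log units; within the scatter) is expected to stay within the scatter, in no clear direction. Compound 3 is estimated at 14000 nM, with a range from 5000 nM to 40000 nM.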

Compound 3, concentration for 50% growth inhibition: 813 nM
Compound 3: middle estimate off by 17-fold (1.24 log units), on the high side, and the stated range ends above it.
By their numbers in this assay, from the lowest: compound 3; then compounds 1 and 2 (each within the scatter of the next).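

In this assay, the added methoxy gives a 20-fold lower number from compound 1 to compound 3 (1.30 log units; beyond the scatter), so this position on the six-membered aromatic ring, ortho to a methoxy group and meta to both a large group and a second methoxy group, clearly affects the read-out. Compounds 1 and 2 differ in more than one place and could not show this. Here a change of only 2 heavy atoms, with the rest of the molecule held constant, moves the number beyond the scatter, although nothing shown explains why.

The compounds shown leave open whether a hydroxyl, a chlorine or an ethoxy group in the same place would have a similar effect. They also leave open whether removing either existing methoxy group from compound 3 would retain the gain.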